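The source may report more compounds than this note shows. Statements on the series, on what has been measured and on what is new or still open speak of the compounds shown alone.

Measured so far in a functional assay on the whole organism for antagonist activity, with Rattus norvegicus as the target; a lower number here means that less compound is needed, a higher number that more compound is needed for the effect
Compound 1 `c1ccc2c(c1)CC2CCCCN1CCN(c2cccc3c2OCCO3)CC1` at 1.43 mg/kg
Compound 2 `C1=C(CCN2CCN(c3cccc4c3OCCO4)CC2)c2ccccc2CC1` at 0.4 mg/kg

Of these two, compound 1 has the higher number, and its gap to compound 2 lies beyond the scatter. Compound 3 `Clc1cccc2c1CC2CCCN1CCN(c2cccc3c2OCCO3)CC1` has not yet been measured. Among the measured compounds shown here, it carries a group of 9 heavy atoms (8 carbon, 1 chlorine; one four-membered non-aromatic ring of carbon only, one six-membered aromatic ring of carbon only) in place of a group of 9 heavy atoms (9 carbon; one four-membered non-aromatic ring of carbon only, one six-membered aromatic ring of carbon only), on a saturated chain carbon, three bonds along the chain from an amine nitrogen in a ring and no measured step speaks directly to this change. The expected step in this assay is a 1.6-fold lower number from compound 1 to compound 3 (0.20 log units; within the scatter) and this estimate points to a somewhat lower number, though not beyond the scatter. Compound 3 is estimated at 0.9 mg/kg with a wide expected range (0.25 mg/kg to 3 mg/kg).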

Compound 3, dose for 50% inhibition: 3.09 mg/kg
Compound 3: middle estimate off by 3.4-fold (0.54 log units), on the low side; measured number outside the range, above it.
By their numbers in this assay, from the lowest: compound 2; then compound 1; then compound 3.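

In this assay the group with chlorine in place of the all-carbon group, on a saturated chain carbon, three bonds along the chain from an amine nitrogen in a ring, gives a 2.2-fold higher number from compound 1 to compound 3 (0.33 log units; beyond the scatter) as the first step read at this position. This change therefore raises the dose needed, by a modest margin. Nothing measured here explains the step. The compounds shown leave open whether a fluorine or a methoxy group in place of the chlorine would move the number the same way. They also leave open how a longer chain would fare.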